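Replacing a Pentyl Chain by Propylamino: an Expectation

A few compounds are considered here, and "the series" means these few. Any claim that something is new, unique, unknown or untested is made for them only; others in the source may bear on it.

Among the compounds with values here, compound 2 `CCCCCC(=O)Nc1ccc(S(=O)(=O)Oc2ccccc2C(C)C)cc1` gives 6300 nM in a functional assay on HT-1080 cells (Homo sapiens) for antiproliferative activity, read by sulforhodamine B assay, with a stated time of 48 h (on this read-out lower numbers stand for stronger inhibition and higher numbers for weaker inhibition), the lowest of the three numbers so far, though its gap to compound 3 lies within the scatter and only its gap to compound 1 lies beyond it. Compound 3 `CCCCCC(=O)Nc1ccc(S(=O)(=O)Oc2ccccc2I)cc1` gives 9600 nM, and compound 1 `CC(=O)Nc1cccc(S(=O)(=O)Oc2ccccc2C(C)C)c1` gives 21000 nM. Within the data shown here, the single one-point step, a 1.5-fold higher number from compound 2 to compound 3 (0.18 log units; within the scatter), concerns another part of the molecule. Compound 4 `CCCNC(=O)Nc1ccc(S(=O)(=O)Oc2ccccc2C(C)C)cc1` differs from compound 2 by propylamino in place of pentyl on a carbonyl carbon. Among the measured compounds shown here, no measured step touches this chain; compound 1 carries a shorter chain on the carbonyl carbon but differs in more than that, so it offers only a hint. The authors' reasoning therefore expects a modest move toward weaker inhibition, a 1.5-fold higher number from compound 2 to compound 4 (0.18 log units; within the scatter), with compound 4 estimated at 9500 nM, within 3000 nM to 30000 nM.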

Compound 4, half-maximal inhibitory concentration: 680 nM
Estimate against measurement, compound 4: 14-fold (1.15 log units) above, outside the stated range (below it).
By their numbers in this assay, from the lowest: compound 4; then compounds 2 and 3 (each within the scatter of the next); then compound 1.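

Within the data shown here, the chain on the carbonyl carbon proves a sensitive position in this assay: propylamino in place of pentyl gives a 9.3-fold lower number from compound 2 to compound 4 (0.97 log units; beyond the scatter), whereas the only earlier one-place step, at another part of the molecule, stayed within the scatter. This single change also swaps five carbons for three carbons and a nitrogen, adding a hydrogen-bond donor, so the compounds cannot separate the nitrogen from the chain length. No evidence explains the gain. Still open, as far as these compounds go, is how pentylamino or methylamino would fare on the same carbonyl carbon. From the compounds shown here alone, whether iodo in place of isopropyl behaves alike alongside propylamino also remains unknown.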